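The compounds below may be only part of what the source reports. "The series", "measured", "known", "first", "only" and "open" are said of these compounds alone.

Measured compounds:
- Compound 1, `COc1cc(OC)c(OC)cc1/C=C/C(=O)c1ccccc1F`, gives 55.3 nM.
- Compound 2, `COc1ccc(C(=O)/C=C/c2cc(OC)c(OC)c(OC)c2)c(F)c1`, gives 50.5 nM.
- Compound 3, `COc1ccc(C(=O)/C=C/c2cc(OC)c(OC)cc2OC)c(F)c1`, gives 72.2 nM.

These three compounds share an enone linker joining two benzene rings, one of which carries a fluoro group and the other several methoxy groups. They were all tested in a functional assay on HCT-15 cells (Homo sapiens) for cytotoxicity, read by MTT assay, with a stated time of 72 h (a lower number here means a stronger inhibitor, a higher number a weaker inhibitor), where compound 1 gives 55.3 nM, compound 2 gives 50.5 nM and compound 3 gives 72.2 nM. All three numbers lie within the scatter of one another, so no ordering among them can be claimed.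

Compound 3 and compound 1 differ in one place, (hydrogen in place of methoxy on an aromatic carbon), and the resulting step in this assay is a 1.3-fold lower number from compound 3 to compound 1 (0.12 log units; within the scatter). Compound 2 and compound 3 are built from the same atoms joined differently; the difference between the two cores is not broken down here.

Compound 4, `COc1cc(/C=C/C(=O)c2ccc(OC)cc2F)cc(OC)c1`, has not yet been tested. It is related to compound 2 by hydrogen in place of methoxy on an aromatic carbon. Within the data shown here, this is the same kind of change as the one from compound 3 to compound 1, but the surroundings differ: in compound 3 the methoxy that leaves sits meta to a fluoro group, whereas in compound 2 it sits ortho to two methoxy groups. Because the earlier step, a 1.3-fold lower number from compound 3 to compound 1 (0.12 log units; within the scatter), stayed within the scatter, a modest step is expected from compound 2 to compound 4, namely a 2.4-fold higher number from compound 2 to compound 4 (0.38 log units; beyond the scatter). The wider range reflects that the place of the change is not the same. Compound 4 is thus estimated to give 120 nM in this assay, with the expectation spanning 45 nM to 400 nM.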

Compound 4, half-maximal inhibitory concentration: 55.3 nM
Estimate against measurement, compound 4: 2.2-fold (0.34 log units) above; the measured number falls inside the stated range.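

In this assay, putting hydrogen in place of a methoxy group on an aromatic carbon gives a 1.1-fold higher number from compound 2 to compound 4 (0.04 log units; within the scatter), so this methoxy group can go from the core of compound 2 with no measurable change in the number. Set beside the earlier example of the same swap, the two steps agree, and on these two cores the change carries over as a small step that cannot be told from repeat-to-repeat variation: the same change on two cores in this assay, a 1.3-fold lower number (0.12 log units; within the scatter) from compound 3 to compound 1 and a 1.1-fold higher number (0.04 log units; within the scatter) from compound 2 to compound 4, 1.4-fold (0.16 log units) apart, within the scatter of two such steps. This does not show that the swap would behave the same way on any other core or in any other assay, and it cannot rule out a small effect hidden inside the scatter, nor does it say why the steps are so small.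

All four compounds keep a fluoro group, at least two methoxy groups and the enone linker, so the compounds shown leave open what happens when those features are changed. On these data alone, whether an amine, a hydroxyl group, a carboxylic acid or a longer chain such as ethoxy in place of a methoxy group would move the number beyond the scatter also remains open.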